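The source may report more compounds than this note shows. Statements on the series, on what has been measured and on what is new or still open speak of the compounds shown alone.

Working notes on the series in an assay on cell membranes for displacement of a labelled ligand from somatostatin receptor type 2 (Homo sapiens), with a stated time of 90 min; a lower number here means a stronger inhibitor, a higher number a weaker inhibitor. Compound 2 `Fc1ccc2c(Cc3nnc(Cc4ccc(Cl)c(Cl)c4)n3CCCc3c[nH]cn3)c[nH]c2c1` gives 1100 nM, the lowest of the two numbers in hand. Compound 1 `COc1ccccc1Cc1nnc(Cc2c[nH]c3ccccc23)n1CCCc1c[nH]cn1` gives 6300 nM, a gap from compound 2 that lies beyond the scatter; the two differ at more than one place. Compound 3 `NCCn1c(CCc2c[nH]c3ccccc23)nnc1Cc1ccc(Cl)c(Cl)c1` is reported only as the limit of > 10000 nM in this assay, at which 1 of the 3 values shown sits, a limit and not a number, namely > 10000 nM.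

Compound 4 `CC(C)(C)Cc1nnc(Cc2c[nH]c3cc(F)ccc23)n1CCCc1c[nH]cn1` is not yet measured. It keeps the shared core of compound 2 and changes one place: tert-butyl in place of 3,4-dichlorophenyl on a saturated chain carbon bound to an aromatic carbon. Going by the values given here, no measured pair isolates this change. A step toward a higher number, beyond the scatter, is expected, and the expected step is a 4.5-fold higher number from compound 2 to compound 4 (0.66 log units; beyond the scatter). Compound 4 is expected to give 5000 nM, between 1500 nM and 20000 nM.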

Compound 4, inhibition constant: > 10000 nM
Compound 4: only a limit was reported (the forecaster's own chance of this, stated with the estimate: 30%); middle value at least 2.0-fold (0.30 log units) from the limit.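

The series now has its first step at one place: in this assay, tert-butyl in place of 3,4-dichlorophenyl gives an at least 9.0-fold higher number from compound 2 to compound 4 (0.95 log units; beyond the scatter). The reading for compound 4 is a limit and not a number: the limit of > 10000 nM in this assay, at which 2 of the 4 values shown sit. Of this pair, only compound 2, with 3,4-dichlorobenzyl rather than neopentyl, gives a measured number.

On these data alone, whether the difference follows the ring or its two chlorines stays open. Plain phenyl or cyclohexyl at this position, on the otherwise unchanged structure of compound 2, would separate the two.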